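The source may report more compounds than this note shows. Statements on the series, on what has been measured and on what is new or still open speak of the compounds shown alone.

Series notes. The shared core of compound 1 `O=C1NCCc2nc(C#Cc3ccccc3)sc21` carries a phenylethynyl arm on the thiazole side and a six-membered saturated ring fused to it; compound 2 `O=C1c2sc(C#Cc3ccccc3)nc2CN1C1CC1` and compound 3 `CN1CCc2nc(C#Cc3ccccc3)sc2C1` vary the saturated ring, and compound 4 `O=S(=O)(C1CC1)N1CCc2nc(C#Cc3ccccc3)sc2C1` is not yet measured.

In an assay on HEK293 cells for negative allosteric modulation of metabotropic glutamate receptor 5 (Homo sapiens), read by FLIPR, with a stated time of 1 h (a lower number here means a stronger inhibitor, a higher number a weaker inhibitor), compound 1 gives only a limit, > 10000 nM. Compound 2 gives 23 nM in this assay. Compound 3 also gives only a limit in this assay, > 10000 nM, so it stands at the weak end of the numbers shown; as noted, (the limit of > 10000 nM in this assay, at which 2 of the 3 values shown sit).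

The change from compound 3 to compound 4 is cyclopropylsulfonyl in place of methyl on an amine nitrogen in a ring. For the measured compounds named here, compound 2, the one numbered member of the set, carries both a carbonyl and a cyclopropyl on the ring nitrogen, and compound 4 brings a cyclopropyl and two acceptors to the same nitrogen; a gain in this assay beyond the scatter is therefore expected, though a limit cannot be excluded.

The expected step from compound 3 to compound 4 in this assay is an at least 33-fold lower number from compound 3 to compound 4 (1.52 log units; beyond the scatter). Compound 4 is estimated at 300 nM in this assay, within 40 nM to 3000 nM.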

Compound 4, half-maximal inhibitory concentration: 34 nM
Beside the measured number, compound 4's estimate is 8.8-fold (0.95 log units) above it, and the stated range ends above it.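

On the amine nitrogen in a ring, cyclopropylsulfonyl in place of methyl gives an at least 290-fold lower number from compound 3 to compound 4 (2.46 log units; beyond the scatter) in this assay, so a change at this one place is enough to carry the series from the limit of the assay to a measured number. For the compounds shown here, the earlier compounds offered no pair differing in one place, and this is the only single change that can be read so far. Compound 3 stands at a limit and not at a number, so the true size of the step stays unknown: the limit of > 10000 nM in this assay, at which 2 of the 4 values shown sit.

The change brings in the sulfonyl and the cyclopropyl together, so the compounds shown do not separate what each contributes. As far as these compounds go, how a methylsulfonyl or an acetyl group on the same nitrogen would read in this assay remains open.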